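From thiophen-3-yl to furan-2-yl: an expected small step

A few compounds are considered here, and "the series" means these few. Any claim that something is new, unique, unknown or untested is made for them only; others in the source may bear on it.

Of the compounds shown here, three that share one core have been measured in a functional assay on the whole organism with Mus musculus as the target; a higher number here means that more compound is needed for the effect, a lower number that less compound is needed. Compound 1 `C[C@@H](NCc1ccc(OCc2ccccc2Cl)cc1)C(N)=O` gives 17.4 mg/kg, compound 2 `C[C@@H](NCc1ccc(OCc2cccs2)cc1)C(N)=O` gives 61.6 mg/kg and compound 3 `C[C@@H](NCc1ccc(OCc2ccsc2)cc1)C(N)=O` gives 114 mg/kg. Compound 3 thus stands at the high end of the numbers together with compound 2, while compound 1 lies apart at the low end. The next structure, compound 4 `C[C@@H](NCc1ccc(OCc2ccco2)cc1)C(N)=O`, has not yet been measured. It differs from compound 3 by furan-2-yl in place of thiophen-3-yl on a saturated chain carbon bound to an oxygen on an aromatic ring. No furan has a measured value yet, so the closest guide is the exchange of one five-membered aromatic ring for another, a 1.9-fold higher number from compound 2 to compound 3 (0.27 log units; within the scatter). The larger steps, a 3.5-fold higher number from compound 1 to compound 2 (0.55 log units; beyond the scatter) and a 6.6-fold higher number from compound 1 to compound 3 (0.82 log units; beyond the scatter), both start from 2-chlorophenyl and bear on this change less directly. A small step, not clearly beyond the scatter, is therefore expected in this assay, leaning slightly towards a lower number. The expected step is a 1.4-fold lower number from compound 3 to compound 4 (0.15 log units; within the scatter). For compound 4 the estimated value is 80 mg/kg, with an expected range of 35 mg/kg to 180 mg/kg.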

Compound 4, dose for half-maximal effect: 116 mg/kg
Compound 4: the middle estimate sits 1.5-fold (0.16 log units) below what was measured; the measured number falls inside the stated range.
By their numbers in this assay, from the lowest: compound 1; then compounds 2, 3 and 4 (each within the scatter of the next).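

In this assay, the first furan at this position, on a saturated chain carbon bound to an oxygen on an aromatic ring, cannot be told apart from either thiophene: the exchange for thiophen-3-yl gives (a 1.0-fold higher number from compound 3 to compound 4 (0.01 log units; within the scatter)) and the exchange for thiophen-2-yl gives (a 1.9-fold higher number from compound 2 to compound 4 (0.27 log units; within the scatter)), so among these three five-membered aromatic rings neither a ring oxygen in place of a ring sulfur nor the point of attachment separates the compounds. The furan also stays as far from 2-chlorophenyl as the thiophenes do (a 6.7-fold higher number from compound 1 to compound 4 (0.82 log units; beyond the scatter)), and with compounds 2, 3 and 4 all apart from compound 1, none of the compounds shown goes against this split between the five-membered rings and 2-chlorophenyl. No measurement at hand accounts for the flat result among the five-membered rings or for the gap to compound 1.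

The compounds shown leave open whether that gap belongs to the chlorine or to the six-membered ring, a question that plain phenyl at the same place would address. They also leave open whether furan-3-yl or a pyridine ring would fall with the five-membered rings or with compound 1.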